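Furan-3-yl for furan-2-yl on a dihydropyrimidine core

The compounds below may be only part of what the source reports. "The series", "measured", "known", "first", "only" and "open" are said of these compounds alone.

Measured compounds:
compound 1 `CC1=C(C(=O)OCc2ccccc2)C(c2ccco2)NC(=S)N1`: 4%
compound 2 `CC1=C(C(=O)OCc2ccccc2)C(c2ccoc2)NC(=S)N1`: 20%
compound 3 `CCSC(=O)C1=C(C)NC(=O)NC1c1ccco1`: 14%

In an assay on membranes from HeLa cells for displacement of a labelled ligand from adenosine receptor A3 (Homo sapiens), read by scintillation counting, with a stated time of 180 min, tested at 1 uM (on this read-out higher numbers stand for more inhibition at the one concentration tested (going by the name of the read-out) and lower numbers for less inhibition), compound 1 gives 4%, while compound 2 gives 20%. Within the data shown here, the two are related by one change, (furan-3-yl in place of furan-2-yl on a saturated ring carbon), and the step of a number 16 percentage points higher from compound 1 to compound 2 (beyond the scatter) is the only measured step of this kind here. Compound 3 `CCSC(=O)C1=C(C)NC(=O)NC1c1ccco1` has a different core; how it differs from compound 1 is not broken down here. In this assay compound 3 gives 14%. Compound 4 `CCSC(=O)C1=C(C)NC(=O)NC1c1ccoc1` is not yet measured; it differs from compound 3 by furan-3-yl in place of furan-2-yl on a saturated ring carbon, the same kind of change as between compound 1 and compound 2, though the place lines differ: the ring atom nearby bears a (ethylsulfanyl)carbonyl group rather than a large group. Because the step of a number 16 percentage points higher from compound 1 to compound 2 (beyond the scatter) was modest and rests on a single pair, only a small rise is expected from compound 3 to compound 4, a number 10 percentage points higher from compound 3 to compound 4 (within the scatter). Compound 4 is estimated at 24%, between 8% and 40%.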

Compound 4, a percentage reported as inhibition, at one concentration (the size of the read-out at that concentration, not a potency): 1%
Compound 4: the middle estimate sits 23 percentage points above what was measured; the measured number lies below the stated range.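

In this assay the same exchange of furan-2-yl for furan-3-yl on a saturated ring carbon gave a number 13 percentage points lower from compound 3 to compound 4 (beyond the scatter), so the step did not carry over from one core to the other with the same direction: the same change on two cores in this assay, a number 16 percentage points higher (beyond the scatter) from compound 1 to compound 2 and a number 13 percentage points lower (beyond the scatter) from compound 3 to compound 4, 29 percentage points apart, beyond the scatter of two such steps

The change therefore cannot be given one fixed effect in this series. These two pairs do not show which difference between the cores goes with the opposite steps, and readings at one concentration say nothing about potency.

The compounds shown leave open how the same exchange would behave with a carboxylic acid or an amine in place of the (ethylsulfanyl)carbonyl group. They also leave open how a thiophen-3-yl group would read on that saturated ring carbon.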